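Chloro to trifluoromethyl on the urea aryl ring

This account rests on a few compounds, and the source may have more. Where it says the series, first, only, none or still open, it means among the compounds named here.

Measured so far in a functional assay on SNB-75 cells (Homo sapiens) for inhibition, read by sulforhodamine B assay, with a stated time of 48 h; a lower number here means that less compound is tolerated, a higher number that more compound is tolerated:
- compound 1 `O=C(Nc1cccc(-n2cc(-c3ccncc3)c(-c3ccc(Cl)c(O)c3)n2)c1)Nc1ccc(Cl)c(Cl)c1` gives only a limit, > 32500 nM; that is the limit (the limit of > 32500 nM in this assay, at which 1 of the 3 values shown sits).
- compound 2 `COc1cc(-c2nn(-c3cccc(NC(=O)Nc4cccc(C(F)(F)F)c4)c3)cc2-c2ccncc2)ccc1Cl` gives 50000 nM.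
- compound 3 `COc1cc(-c2nn(-c3cccc(NC(=O)c4ccccc4)c3)cc2-c2ccncc2)ccc1Cl` gives only a limit, > 100000 nM; that is the limit (the limit of > 100000 nM in this assay, at which 1 of the 3 values shown sits).

Compound 1 thus stands at a limit of this assay, and all three values sit near the top of its range. For the measured compounds named here, the single measured step, an at least 2.0-fold higher number from compound 2 to compound 3 (0.30 log units; that floor lies within the scatter), alters the group on the carbonyl carbon, not the aryl ring of the urea, so no measured step bears on the change to compound 4 `O=C(Nc1cccc(-n2cc(-c3ccncc3)c(-c3ccc(Cl)c(O)c3)n2)c1)Nc1ccc(Cl)c(C(F)(F)F)c1`: trifluoromethyl in place of chloro on an aromatic carbon. Lacking any relevant comparison, compound 4 is expected to stay near compound 1, with an estimated value of 40000 nM, from 15000 nM to 100000 nM. The expected step that the limit leaves unreadable from compound 1 to compound 4 is estimated to carry no direction beyond the scatter, and a limit rather than a number is a likely outcome.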

Compound 4, concentration lethal to 50% of the cells: > 32500 nM
Compound 4 was reported as a limit; the forecaster's own chance of this, stated with the estimate: 60%; the middle value is on the limit's open side.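

Compound 1 and compound 4 both stand at the same limit of this assay, so trifluoromethyl in place of chloro gives no readable step: the limit of > 32500 nM in this assay, at which 2 of the 4 values shown sit.

The compounds shown leave open whether either aryl group on the urea affects this read-out at concentrations within the assay's range.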